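This account rests on a few compounds, and the source may have more. Where it says the series, first, only, none or still open, it means among the compounds named here.

Three compounds share one core and differ only in the group on one aromatic carbon of it. In a functional assay on HEK293 cells for antagonist activity at transient receptor potential cation channel subfamily V member 1 (Homo sapiens), read by FLIPR and calcium flux (on this read-out higher numbers stand for weaker inhibition and lower numbers for stronger inhibition), compound 1 `NC1CCN(c2nc3c(c(Nc4ccc(C(F)(F)F)cc4)n2)CCN(c2ncccc2C(F)(F)F)CC3)C1` gives 3700 nM and compound 2 `CN(c1nc2c(c(Nc3ccc(C(F)(F)F)cc3)n1)CCN(c1ncccc1C(F)(F)F)CC2)C1CCCNC1` gives 3600 nM; these two lie within the scatter of each other, as a 1.0-fold lower number from compound 1 to compound 2 (0.01 log units; within the scatter) shows. Compound 3 `FC(F)(F)c1ccc(Nc2nc(N3CCN(C4CCC4)CC3)nc3c2CCN(c2ncccc2C(F)(F)F)CC3)cc1` gives 24 nM in this assay, the lowest of the three numbers, reached by the large steps of a 150-fold lower number from compound 1 to compound 3 (2.19 log units; beyond the scatter) and a 150-fold lower number from compound 2 to compound 3 (2.18 log units; beyond the scatter). Compound 4 `CN1CCCCC1CNc1nc2c(c(Nc3ccc(C(F)(F)F)cc3)n1)CCN(c1ncccc1C(F)(F)F)CC2` takes the next step: ((1-methylpiperidin-2-yl)methyl)amino in place of 4-cyclobutylpiperazin-1-yl on an aromatic carbon. Both large steps came when a 3-aminopyrrolidin-1-yl or methyl(piperidin-3-yl)amino group gave way to the 4-cyclobutylpiperazin-1-yl group of compound 3; compound 4 moves back toward an amino-linked group, so a higher number is expected in this assay, though its size is uncertain. Compound 4 is therefore estimated at 400 nM, with a range from 50 nM to 3000 nM, an expected step of a 17-fold higher number from compound 3 to compound 4 (1.22 log units; beyond the scatter).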

Compound 4, half-maximal inhibitory concentration: 1760 nM
Beside the measured number, compound 4's estimate is 4.4-fold (0.64 log units) below it, and the stated range covers the measured number.
By their numbers in this assay, from the lowest: compound 3; then compound 4; then compounds 2 and 1 (each within the scatter of the next).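

In this assay the ((1-methylpiperidin-2-yl)methyl)amino group gives up nearly all of the advantage held by the 4-cyclobutylpiperazin-1-yl group (a 73-fold higher number from compound 3 to compound 4 (1.87 log units; beyond the scatter)). The steps from the other two groups are only modest (a 2.0-fold lower number from compound 2 to compound 4 (0.31 log units; beyond the scatter); a 2.1-fold lower number from compound 1 to compound 4 (0.32 log units; beyond the scatter)), so at this position compound 3 stands well apart from the other three compounds, which differ far less among themselves. Nothing available explains this gap. From the compounds shown here alone, it remains open whether the low number of compound 3 depends on its cyclobutyl ring or on the piperazine ring. A 4-methylpiperazin-1-yl or an unsubstituted piperazin-1-yl group at this position would help separate the two.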